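Double-bond configuration: from compound 2 to compound 4

This account rests on a few compounds, and the source may have more. Where it says the series, first, only, none or still open, it means among the compounds named here.

- compound 1 `CC/C(=C(\c1ccccc1)c1ccc(NC(=O)C(C)C)cc1)c1ccccc1`: > 30000 nM
- compound 2 `CC/C(=C(\c1ccccc1)c1ccc(NC(=O)C(C)C)cc1)c1ccc(Cl)cc1Cl`: 8300 nM
- compound 3 `CC/C(=C(/c1ccc(NC(=O)C(C)C)cc1)c1ccc(OC)cc1)c1ccc(Cl)cc1Cl`: 6600 nM

The value for compound 1 is a limit of the assay. For the measured compounds named here, in a functional assay on MCF7 cells (Homo sapiens) for inhibition, read by trypan blue exclusion, with a stated time of 72 h (on this read-out higher numbers stand for weaker inhibition of growth and lower numbers for stronger inhibition of growth), compound 2 stands level with compound 3, the only other true number, within the scatter.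

Compound 4 `CC/C(=C(/c1ccccc1)c1ccc(NC(=O)C(C)C)cc1)c1ccc(Cl)cc1Cl` is the next case: the two compounds have the same atoms and bonds and differ only in configuration as drawn: 1 of 1 stereo elements differ; a double bond is drawn Z in compound 2 and E in compound 4. Two measured steps are nearby, an at least 3.6-fold lower number from compound 1 to compound 2 (0.55 log units; beyond the scatter) and a 1.3-fold lower number from compound 2 to compound 3 (0.10 log units; within the scatter), but each alters a substituent and leaves the configuration unchanged. They therefore give no direction, and no shift beyond the scatter is assumed, though with wide uncertainty. The expected step is a 1.2-fold higher number from compound 2 to compound 4 (0.08 log units; within the scatter). For compound 4 the estimated value is 10000 nM, with an expected range of 3000 nM to 30000 nM.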

Compound 4, concentration for 50% growth inhibition: 17500 nM
Estimate against measurement, compound 4: 1.8-fold (0.24 log units) below; the measured number falls inside the stated range.
By their numbers in this assay, from the lowest: compounds 3 and 2 (each within the scatter of the next); then compound 4. At a limit, above all of these: compound 1.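

Of the steps shown, a 2.1-fold higher number from compound 2 to compound 4 (0.32 log units; beyond the scatter) in this assay is the only one that changes configuration rather than a substituent, and it is modest. For the compounds shown here, the double bond therefore counts at this position: the earlier steps moved substituents and left its configuration unchanged. The gap can be assigned to configuration alone because nothing else changes: the fact that compounds 2 and 4 differ only in the configuration as drawn

Open, from the compounds shown here alone, is whether this step keeps its direction and size with the methoxy group of compound 3. Also open, going by these compounds, is how an amine or a carboxylic acid on the shared core would read in this assay.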